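This account rests on a few compounds, and the source may have more. Where it says the series, first, only, none or still open, it means among the compounds named here.

Measured so far in a functional assay on MCF7 cells (Homo sapiens) for antiproliferative activity, read by MTT assay, with a stated time of 48 h (on this read-out higher numbers stand for weaker inhibition and lower numbers for stronger inhibition), are two compounds:
Compound 1 `CC(C)=CCC[C@]1(C)/C=C/[C@@H](OC(=O)C=C(C)C)[C@](C)(O)/C=C/C(=O)/C(C(=O)O)=C\C1` gives 16100 nM
Compound 2 `CC(C)=CCC[C@]1(C)/C=C/[C@@H](OC(=O)C=C(C)C)[C@](C)(O)/C=C/C(=O)/C(C[Si](C)(C)C(C)(C)C)=C\C1` gives 6040 nM

Of these two, compound 2 (6040 nM) holds the lower number. Compound 3 (`CCN(CC)C(=O)/C1=C/C[C@](C)(CCC=C(C)C)/C=C/[C@@H](OC(=O)C=C(C)C)[C@](C)(O)/C=C/C1=O`) differs from compound 2 in one place, on a double-bonded ring carbon, where diethylcarbamoyl enters (a group of 7 heavy atoms (5 carbon, 1 nitrogen, 1 oxygen; no ring) in place of a group of 8 heavy atoms (7 carbon, 1 silicon; no ring), on a double-bonded ring carbon). Within the data shown here, no measured compound carries diethylcarbamoyl, so the only guide is the single step at this same place (a 2.7-fold lower number from compound 1 to compound 2 (0.43 log units; beyond the scatter)), which was modest. A change no larger than that one is therefore expected in this assay, leaning slightly toward a higher number and probably staying within the scatter. The estimated change (a 1.3-fold higher number from compound 2 to compound 3 (0.12 log units; within the scatter)) is small, and the evidence for it is thin. The estimate for compound 3 is 8000 nM (expected range 3000 nM to 20000 nM).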

Compound 3, half-maximal inhibitory concentration: 12100 nM
For compound 3 the middle estimate is 1.5-fold (0.18 log units) below the measured one, within the range that was stated.
By their numbers in this assay, from the lowest: compounds 2, 3 and 1 (each within the scatter of the next, the first and the last beyond it).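

In this assay, diethylcarbamoyl in place of the silicon-bearing group on the double-bonded ring carbon yields a step within the scatter (a 2.0-fold higher number from compound 2 to compound 3 (0.30 log units; within the scatter)), and diethylamino in place of hydroxy on the carbonyl carbon does the same (a 1.3-fold lower number from compound 1 to compound 3 (0.12 log units; within the scatter)). Compound 3 therefore cannot be separated from either of the other two on this read-out, and at this place the amide cannot be told apart from the carboxylic acid. Nothing available explains these numbers.

The compounds shown leave open whether a smaller amide, such as a primary amide or a dimethylamide, or a cyclic one such as a morpholine amide, would stay in this same range. They also leave open how a methyl ester or a hydroxymethyl group at this carbon would read.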